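The source may report more compounds than this note shows. Statements on the series, on what has been measured and on what is new or still open speak of the compounds shown alone.

Measured so far:
Compound 1, `COc1cc(NC(C)CCCN2C(=O)[C@@H](C)N(C(=O)CN)C2(C)C)c2ncccc2c1`, in a physicochemical assay for lipophilicity, measured as octanol-water partition; on this read-out lower numbers stand for lower lipophilicity and higher numbers for higher lipophilicity: 2.54
Compound 2, `COc1cc(NC(C)CCCN2C(=O)CN(C(=O)[C@@H](C)N)C2(C)C)c2ncccc2c1`, in this assay: 2.49

Compound 2 and compound 1 lie within the scatter of each other in this assay, so neither stands apart from the other on these numbers. Compound 3, `COc1cc(NC(C)CCCN2C(=O)CN(C(=O)CN)C2(C)C)c2ncccc2c1`, differs from compound 2 by hydrogen in place of methyl on a saturated chain carbon bound to an amine nitrogen and a carbonyl carbon. Among the compounds with values here, no measured pair shows this change, so its size in this assay cannot be read from the data at hand. Compound 3 is expected to come out a little lower, by a number 0.34 log units lower from compound 2 to compound 3 (beyond the scatter), a step only just beyond the scatter. Compound 3 is therefore estimated at 2.15, with a range from 1.85 to 2.45.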

Compound 3, partition coefficient: 2.19
Compound 3: the middle estimate sits 0.04 log units below what was measured; low and high end bracket the measured number.
By their numbers in this assay, from the lowest: compounds 3, 2 and 1 (each within the scatter of the next, the first and the last beyond it).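

In this assay, hydrogen in place of methyl on a saturated chain carbon bound to an amine nitrogen and a carbonyl carbon gives a number 0.30 log units lower from compound 2 to compound 3 (within the scatter), so this single change at this position does not stand clear of the scatter. Hydrogen in place of methyl on a saturated ring carbon gives a number 0.35 log units lower from compound 1 to compound 3 (beyond the scatter), a modest step and the only one of the two beyond the scatter. Nothing at hand explains either step.

The compounds shown leave open how this read-out responds at either place to an ethyl group or a longer chain. They also leave open what a carboxylic acid in place of the amine of the aminomethyl group would give.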